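From cyclopropyl to phenyl on the shared core

This account rests on a few compounds, and the source may have more. Where it says the series, first, only, none or still open, it means among the compounds named here.

- compound 1 `Nc1ccccc1Nc1n[n+]([O-])c2ccccc2[n+]1[O-]` gives 10600 nM
- compound 2 `[O-][n+]1nc(NC2CC2)[n+]([O-])c2ccccc21` gives 6600 nM
- compound 3 `CCN(CC)c1n[n+]([O-])c2ccccc2[n+]1[O-]` gives > 55000 nM (a limit of the assay, not a number)

In a functional assay on K562 cells (Homo sapiens) for cytotoxicity, read by MTT assay, with a stated time of 48 h (a higher number here means a weaker inhibitor, a lower number a stronger inhibitor), compound 2 gives 6600 nM and compound 1 gives 10600 nM, two values within the usual scatter of each other. Compound 3 gives only a limit, > 55000 nM.

The next structure is compound 4 `[O-][n+]1nc(Nc2ccccc2)[n+]([O-])c2ccccc21`, which differs from compound 2 by one swap: phenyl in place of cyclopropyl on a nitrogen on an aromatic ring. For the measured compounds named here, only one measured step bears on this place, an at least 8.3-fold higher number from compound 2 to compound 3 (0.92 log units; beyond the scatter). Going by the values given here, it involves a different group, so it shows only that a change here can matter. Compound 1 also carries a six-membered aromatic ring of carbon only on that nitrogen, and compound 1 gives 10600 nM. On that basis, no step beyond the scatter is expected in this assay, though a larger move remains possible. The expected change is a 1.4-fold higher number from compound 2 to compound 4 (0.13 log units; within the scatter). For compound 4 the estimated value is 9000 nM, with an expected range of 3500 nM to 25000 nM.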

Compound 4, half-maximal inhibitory concentration: 2400 nM
Compound 4: the middle estimate sits 3.8-fold (0.57 log units) above what was measured, and the stated range ends above it.
By their numbers in this assay, from the lowest: compound 4; then compounds 2 and 1 (each within the scatter of the next). At a limit, above all of these: compound 3.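

In this assay, for the compounds shown here, this position can also move downward: phenyl in place of cyclopropyl on the nitrogen gives a 2.8-fold lower number from compound 2 to compound 4 (0.44 log units; beyond the scatter), whereas the one earlier step here went upward. The amino group on that phenyl also matters, as hydrogen in place of amino gives a 4.4-fold lower number from compound 1 to compound 4 (0.65 log units; beyond the scatter), so the close earlier values did not show what the unsubstituted phenyl could do. Nothing measured here gives a reason for either step.

The compounds shown leave open whether another group on the phenyl, such as a hydroxyl, a methoxy or a carboxylic acid, would take the number lower still. They also leave open whether a benzyl group or a longer carbon chain on the nitrogen would keep this gain.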